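The source may report more compounds than this note shows. Statements on the series, on what has been measured and on what is new or still open speak of the compounds shown alone.

Measured so far, in a functional assay on BXPC-3 cells (Homo sapiens) for inhibition, read by MTT assay, with a stated time of 72 h; a lower number here means a stronger inhibitor, a higher number a weaker inhibitor:
- compound 1 `COc1cc(NC(=O)c2cnc(C)cn2)c2ncccc2c1`: 6700 nM
- compound 2 `COc1cc(NC(=O)c2ncccn2)c2ncccc2c1`: a limit of the assay, > 10000 nM

Among the measured compounds shown here, compound 1 is the only compound with an actual number in this assay; the other value shown is a limit (the limit of > 10000 nM in this assay, at which 1 of the 2 values shown sits). For the measured compounds named here, the one measured step, an at least 1.4-fold higher number from compound 1 to compound 2 (0.17 log units; that floor lies within the scatter), swaps the ring attached to the carbonyl carbon, and because compound 2 sits at a limit of > 10000 nM in this assay, at which 1 of the 2 values shown sits, its true size is not known beyond its floor, which lies within the usual scatter.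

Compound 3 `Cc1cnc(C(=O)Nc2cc(OCCC3CCNCC3)cc3cccnc23)cn1` differs from compound 1 in a different place: (piperidin-4-yl)methyl in place of hydrogen on a saturated chain carbon bound to an oxygen on an aromatic ring. The measured step changed the ring on the carbonyl carbon, not the chain on the ether oxygen, so it gives no guide to the size or direction of this change in this assay. With nothing measured that bears on it, the expectation stays close to the number for compound 1, with a wide range. Compound 3 is therefore expected to give an estimated 4000 nM, between 700 nM and 20000 nM. That estimate means an expected 1.7-fold lower number from compound 1 to compound 3 (0.22 log units; within the scatter).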

Compound 3, half-maximal inhibitory concentration: 8330 nM
Beside the measured number, compound 3's estimate is 2.1-fold (0.32 log units) below it, within the range that was stated.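

Among the compounds shown here, this is the first reading at the oxygen on the aromatic ring of the shared core: exchanging methoxy for 2-(piperidin-4-yl)ethoxy gives a 1.2-fold higher number from compound 1 to compound 3 (0.09 log units; within the scatter), so the two compounds cannot be told apart in this assay. A chain ending in a six-membered non-aromatic ring can therefore be carried at this place with no measurable difference in this read-out, something the earlier step, made on the ring attached to the carbonyl carbon, could not show. Nothing measured here offers an explanation for this result.

Still open, as far as these compounds go, is whether the ring nitrogen of the piperidine matters at all: a cyclohexyl ring on the same chain, a shorter or longer chain, or an open-chain amine such as a dimethylamino group at the end of the chain could each read differently in this assay. Also open, from the compounds shown here alone, is how pyrimidin-2-yl on the carbonyl carbon would read when combined with the 2-(piperidin-4-yl)ethoxy group.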